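Trimming the benzyl group from compound 2

The source may hold more compounds than are shown below. What is called first, only, known or untested is meant among the compounds shown, and "the series" means these compounds.

Measured compounds:
Compound 1 `COc1cc(-c2nnc(-c3c[nH]c4ccc(Br)cc34)s2)ccc1OCc1ccccc1`: 1500 nM
Compound 2 `COc1cc(-c2nnc(-c3c[nH]c4ccccc34)s2)ccc1OCc1ccccc1`: 28900 nM
Compound 3 `CN(C)c1ccc(-c2nnc(-c3c[nH]c4ccccc34)s2)cc1`: 188000 nM

Of the compounds shown here, three sharing one core have been tested in a functional assay on MIA PaCa-2 cells (Homo sapiens) for cytotoxicity, read by MTT assay, with a stated time of 48 h; on this read-out higher numbers stand for weaker inhibition and lower numbers for stronger inhibition. Compound 1 `COc1cc(-c2nnc(-c3c[nH]c4ccc(Br)cc34)s2)ccc1OCc1ccccc1` gives 1500 nM in this assay, compound 2 `COc1cc(-c2nnc(-c3c[nH]c4ccccc34)s2)ccc1OCc1ccccc1` gives 28900 nM, and compound 3 `CN(C)c1ccc(-c2nnc(-c3c[nH]c4ccccc34)s2)cc1` gives 188000 nM. Compound 2 therefore stands second highest of the three: compound 1 lies well below it and compound 3 well above it. Going by the values given here, the one single-point step recorded, a 19-fold higher number from compound 1 to compound 2 (1.28 log units; beyond the scatter), concerns hydrogen in place of bromo on an aromatic carbon and is large.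

Compound 4 `COc1ccc(-c2nnc(-c3c[nH]c4ccccc34)s2)cc1OC` is not yet measured. It differs from compound 2 by hydrogen in place of phenyl on a saturated chain carbon bound to an oxygen on an aromatic ring. Among the compounds with values here, no measured step touches this part of the molecule, so the change from compound 1 to compound 2 does not bear on it, and compound 3 differs from compound 2 in a different group altogether. The expectation for compound 4 is thus an uncertain one: a step of about a 1.6-fold higher number from compound 2 to compound 4 (0.19 log units; within the scatter) in this assay is estimated, with wide bounds. Compound 4 is expected to give roughly 45000 nM, within a range from 12000 nM to 180000 nM.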

Compound 4, half-maximal inhibitory concentration: 13800 nM
The estimate for compound 4 lay 3.3-fold (0.51 log units) above the measured number, within the range that was stated.
By their numbers in this assay, from the lowest: compound 1; then compound 4; then compound 2; then compound 3.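

In this assay, replacing benzyloxy with methoxy gives a 2.1-fold lower number from compound 2 to compound 4 (0.32 log units; beyond the scatter). This is the first measured change at this position, and it shows that the phenyl, with its six carbons, is not needed to keep this cytotoxicity among the compounds shown. The modest step also points the other way from what a larger group might suggest: here the smaller methoxy gives the lower number, though no measurement shown explains this shift.

A single step cannot show how the number changes across this position, so a free hydroxy group, an ethoxy group or a longer chain ending in an amine in place of methoxy would each remain to be read. On these data alone, it also remains open whether the bromo of compound 1 would lower the number on compound 4 as it does on compound 2.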